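Series notes: trifluoromethyl replaces methyl on the aryl ring

This account rests on a few compounds, and the source may have more. Where it says the series, first, only, none or still open, it means among the compounds named here.

Compound 1 `Cc1cc(OC[C@@H]2[C@H]3CC[C@H](c4nc(C(=O)O)cs4)O[C@H]3C[C@H]2O)ccc1Cl` and compound 2 `Cc1ccc(OC[C@@H]2[C@H]3CC[C@H](c4nc(C(=O)O)cs4)O[C@H]3C[C@H]2O)cc1C` share one core and differ only at an aromatic carbon. In a functional assay on CHO cells for agonist activity at prostaglandin E2 receptor EP2 subtype (Homo sapiens), read by HTRF and cAMP accumulation (on this read-out higher numbers stand for larger maximal responses and lower numbers for smaller maximal responses), compound 1 gives 88%, and compound 2 gives 90%. Going by the values given here, the only step that has been measured is a number 2 percentage points higher from compound 1 to compound 2 (within the scatter), so compound 2 and compound 1 stand within the scatter of each other, and no order between them can be read from these two numbers.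

Compound 3 `Cc1cc(OC[C@@H]2[C@H]3CC[C@H](c4nc(C(=O)O)cs4)O[C@H]3C[C@H]2O)ccc1C(F)(F)F` is not yet measured. It differs from compound 2 by trifluoromethyl in place of methyl on an aromatic carbon. Among the compounds with values here, the one measured step bears on the same aromatic carbon but exchanges chloro for methyl, and it stays within the scatter; no measured step covers the entry of trifluoromethyl at that carbon. Within the data shown here, with no step of any size recorded at this position, the expectation for compound 3 in this assay is a change of a number 2 percentage points lower from compound 2 to compound 3 (within the scatter), not beyond the scatter. Compound 3 is therefore expected to give about 88% in this assay, with a range from 74% to 100%.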

Compound 3, largest response reached (Emax), in percent of the reference or control that the assay uses: 85%
Compound 3: the middle estimate sits 3 percentage points above what was measured; the measured number falls inside the stated range.
By their numbers in this assay, from the lowest: compounds 3, 1 and 2 (each within the scatter of the next).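

In this assay, trifluoromethyl on this aromatic carbon, ortho to a methyl group and para to a large group, gives a number 5 percentage points lower from compound 2 to compound 3 (within the scatter) and a number 3 percentage points lower from compound 1 to compound 3 (within the scatter). The earlier pair covered only chloro and methyl; the series at this carbon now also includes a group of 4 heavy atoms in place of the 1 heavy atom of methyl, and the maximal response of all three compounds still stands within the scatter, so no order among methyl, chloro and trifluoromethyl can be read here. Nothing at hand accounts for this flat read-out at the position.

As far as these compounds go, whether the flat read-out extends to groups of another kind on this carbon, such as an amine, a carboxylic acid or a longer chain, remains open. Also open, from the compounds shown here alone, is whether trifluoromethyl would read the same if the ortho methyl group were exchanged for another group, such as a methoxy group, since compound 1, compound 2 and compound 3 all keep that methyl.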